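Removing a Cyclopropylmethyl Group: an Expected Shift in Maximal Response

A few compounds are considered here, and "the series" means these few. Any claim that something is new, unique, unknown or untested is made for them only; others in the source may bear on it.

Compound 1 `FC(F)(F)Cc1cnc2c(Cl)c(-c3cc(Cl)c4c(ccn4CC4CC4)c3)ccn12`: 193%
Compound 2 `N#Cc1c(-c2ccc3c(c2)OCCN3)ccn2c(CC(F)(F)F)cnc12`: 232%

In a functional assay on CHO cells for agonist activity at metabotropic glutamate receptor 2 (Homo sapiens) (on this read-out higher numbers stand for larger maximal responses and lower numbers for smaller maximal responses), compound 1 gives 193%, the lower of the two numbers. Compound 2 gives 232%, a gap from compound 1 that lies beyond the scatter. Compound 3 `FC(F)(F)Cc1cnc2c(Cl)c(-c3cc(Cl)c4[nH]ccc4c3)ccn12` differs from compound 1 by hydrogen in place of cyclopropylmethyl on an aromatic nitrogen. Among the measured compounds shown here, no measured pair covers this change, so its size is not known from the data. Compound 3 is expected to land near 175%, between 125% and 225%. The expected step of a number 18 percentage points lower from compound 1 to compound 3 (beyond the scatter) is a small decrease, hardly beyond the scatter.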

Compound 3, largest response reached (Emax), in percent of the reference or control that the assay uses: 217%
Estimate against measurement, compound 3: 42 percentage points below; measured number inside the range.
By their numbers in this assay, from the lowest: compound 1; then compound 3; then compound 2.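

In this assay the replacement of cyclopropylmethyl by hydrogen on the aromatic nitrogen now has a measured size, a number 24 percentage points higher from compound 1 to compound 3 (beyond the scatter), and it is a rise. The cyclopropylmethyl group is therefore not required for a large maximal response at this position, since compound 3 still reaches 217% with only hydrogen there. Nothing at hand explains the direction of this step. Still open, on these data alone, is how a methyl group, or a longer chain such as butyl, on this nitrogen would compare with compound 1 and compound 3.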